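The compounds below may be only part of what the source reports. "The series", "measured", "known", "first", "only" and "open" are said of these compounds alone.

Compound 1, `Cn1c([N+](=O)[O-])cnc1C(=O)NCc1ccc(F)cc1`: in a toxicity assay on HepG2 cells (Homo sapiens) for inhibition, read by resazurin assay, with a stated time of 24 h (a higher number here means that more compound is tolerated, a lower number that less compound is tolerated), compound 1 gives > 100000 nM, which is a limit of the assay and not a number.
Compound 2, `Cn1c([N+](=O)[O-])cnc1C(=O)NCc1ccccn1`: in this assay compound 2 gives > 100000 nM, again a limit rather than a number.
Compound 3, `O=C(NCc1ccc(F)cc1)c1ncc([N+](=O)[O-])[nH]1`: in this assay compound 3 gives > 100000 nM, also a limit.

Compound 4, `O=C(NCc1ccccn1)c1ncc([N+](=O)[O-])[nH]1`, has not yet been measured in this assay. It differs from compound 2 in one place: hydrogen in place of methyl on an aromatic nitrogen. The same change separates compound 1 from compound 3, (hydrogen in place of methyl on an aromatic nitrogen), and its measured size there is a step that the two limits leave unreadable from compound 1 to compound 3. How the core of compound 1 differs from the core of compound 2 is not broken down here. All three measured values share one feature, (the limit of > 100000 nM in this assay, at which 3 of the 3 values shown sit), so no difference between any two of them can be read.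

Going by the values given here, for the step from compound 2 to compound 4 a similarly unreadable, essentially flat outcome is expected, a step that the limit leaves unreadable from compound 2 to compound 4, because the same change gave a step that the two limits leave unreadable from compound 1 to compound 3 and because every value so far sits at the limit of > 100000 nM in this assay, at which 3 of the 3 values shown sit. Compound 4 is therefore estimated at 150000 nM, most probably reported once more only as a limit, within a range from 60000 nM to 400000 nM.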

Compound 4, half-maximal cytotoxic concentration: > 100000 nM
Compound 4 was reported as a limit; the forecaster's own chance of this, stated with the estimate: 85%; the middle value does not contradict the limit.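

In this assay compound 4 gives > 100000 nM, a limit of the assay and not a number. No step can therefore be read from compound 2 to compound 4, and the values of compounds 1 to 4 share one feature: the limit of > 100000 nM in this assay, at which 4 of the 4 values shown sit.

The compounds shown leave open what concentration any of them would take to harm the cells, and whether swapping methyl for hydrogen changes that concentration at all.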